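The source may report more compounds than this note shows. Statements on the series, on what has been measured and on what is new or still open speak of the compounds shown alone.

In an ADME assay on HFF cells (Homo sapiens) for cytotoxicity, with a stated time of 8 days (on this read-out higher numbers stand for lower toxicity in this test and lower numbers for higher toxicity in this test), compound 1 `C=CCOc1nc(N)nc2c1ncn2/C=C1/CC1(CO)CO` gives > 300000 nM as a limit of the assay, not a number. Compound 2 `Nc1nc(NC2CC2)c2ncn(/C=C3/CC3(CO)CO)c2n1` gives > 300000 nM as a limit too. From the compounds shown here alone, compound 3 `CCCNc1nc(N)nc2c1ncn2/C=C1/CC1(CO)CO` likewise gives > 300000 nM as a limit, so its exact place on the scale is unknown. The next structure, compound 4 `CCCCCCSc1nc(N)nc2c1ncn2/C=C1/CC1(CO)CO`, carries hexylsulfanyl in place of the propylamino of compound 3 on an aromatic carbon, a change counted as hexylsulfanyl in place of propylamino on an aromatic carbon in full.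

The measured steps at this position are a step that the two limits leave unreadable from compound 1 to compound 2 and a step that the two limits leave unreadable from compound 1 to compound 3 and also a step that the two limits leave unreadable from compound 2 to compound 3 within the same group, yet none has a size to carry over. What they offer is the limit of > 300000 nM in this assay, at which 3 of the 3 values shown sit, and nothing finer. A readable number for compound 4 could therefore only lie lower, toward higher toxicity. The step expected in this assay is an at least 2.0-fold lower number from compound 3 to compound 4 (0.30 log units; that floor lies within the scatter) and a repeat of the limit also remains quite possible. For compound 4 the estimated value is 150000 nM with an expected range from 40000 nM to 300000 nM in this test.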

Compound 4, half-maximal cytotoxic concentration: > 300000 nM
Compound 4: only a limit was reported; the forecaster's own chance of this, stated with the estimate: 50%; middle value at least 2.0-fold (0.30 log units) away from the limit.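

Compound 4 also gives only a limit of the assay, so its steps from compound 1, compound 2 and compound 3 in this assay cannot be read, and what remains is this: the limit of > 300000 nM in this assay, at which 4 of the 4 values shown sit. The compounds shown leave open whether these four groups on the aromatic carbon differ at all in this test.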